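The source may hold more compounds than are shown below. What is called first, only, known or untested is meant among the compounds shown, and "the series" means these compounds.

Measured so far in an in vitro assay on HEK-tsA201 cells for antagonist activity at Neuronal acetylcholine receptor; alpha4/beta2 (Homo sapiens), read by fluorescence and calcium flux; a higher number here means a weaker inhibitor, a lower number a stronger inhibitor:
Compound 1, `C=CCOc1ccc(C(=O)Nc2cccc(Cl)n2)cc1`, gives > 100000 nM, which is a limit of the assay and not a number.
Compound 2, `CCCOc1ccc(C(=O)Nc2cccc(Br)n2)cc1`, gives 80700 nM.
Compound 3, `CCCOc1ccc(C(=O)Nc2cccc(Cl)n2)cc1`, gives > 100000 nM, again a limit of the assay.

Compound 3 therefore stands at the limit of > 100000 nM in this assay, at which 2 of the 3 values shown sit. Of the measured steps, an at least 1.2-fold higher number from compound 2 to compound 3 (0.09 log units; that floor lies within the scatter) lies within the scatter, and a step that the two limits leave unreadable from compound 1 to compound 3 cannot be read because of the two limits. Compound 4, `CCCNc1cccc(NC(=O)c2ccc(OCCC)cc2)n1`, differs from compound 3 by propylamino in place of chloro on an aromatic carbon. Neither measured step resembles this change, so no size or direction of step in this assay can be expected on firm ground, and a limit may again be reported. Compound 4 is estimated at 70000 nM, between 15000 nM and 300000 nM. That estimate would correspond to an at least 1.4-fold lower number from compound 3 to compound 4 (0.15 log units; that floor lies within the scatter) in this assay, if a number is obtained at all.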

Compound 4, half-maximal inhibitory concentration: 15400 nM
The estimate for compound 4 lay 4.5-fold (0.66 log units) above the measured number; the measured number falls inside the stated range.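

In this assay, swapping the halogen next to the ring nitrogen for propylamino gives an at least 6.4-fold lower number from compound 3 to compound 4 (0.81 log units; beyond the scatter) and a 5.2-fold lower number from compound 2 to compound 4 (0.72 log units; beyond the scatter). This position therefore admits a larger group with a hydrogen-bond donor, and inhibition strengthens beyond the scatter. The first step is only a floor because compound 3 gives a limit of the assay, not a number: the limit of > 100000 nM in this assay, at which 2 of the 4 values shown sit.

As far as these compounds go, whether the chain or the nitrogen drives the step remains open. A plain amino group, dimethylamino or a longer chain such as butylamino would separate the two.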